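Working notes on a short antiproliferative series

A few compounds are considered here, and "the series" means these few. Any claim that something is new, unique, unknown or untested is made for them only; others in the source may bear on it.

Measured so far in a functional assay on A549 cells (Homo sapiens) for antiproliferative activity, read by MTT assay, with a stated time of 72 h; on this read-out lower numbers stand for stronger inhibition and higher numbers for weaker inhibition:
- compound 1 `CN(C(=O)C(C)(C)C)c1ccc2[nH]c(-c3n[nH]c4ccccc34)cc2n1`: 24400 nM
- compound 2 `CN(c1ccc2[nH]c(-c3n[nH]c4ccccc34)cc2n1)S(=O)(=O)c1ccccc1`: 14000 nM

Going by the values given here, compound 2 has the lower of the two numbers recorded, and compound 1 is its only neighbour; the change from one to the other, a 1.7-fold lower number from compound 1 to compound 2 (0.24 log units; within the scatter), lies within the scatter, so the two compounds are not separated by these data.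

Compound 3 `CN(c1ccc2[nH]c(-c3n[nH]c4ccccc34)cc2n1)S(=O)(=O)c1ccc(OC(F)(F)F)cc1` differs from compound 2 in one place: trifluoromethoxy in place of hydrogen on an aromatic carbon. Among the compounds with values here, no measured step touches this position. Within the data shown here, the single step recorded, a 1.7-fold lower number from compound 1 to compound 2 (0.24 log units; within the scatter), concerns exchange of the whole group on the ring nitrogen rather than substitution of the phenyl, and it was itself within the scatter. There is therefore no measured basis for a step beyond the scatter in either direction in this assay.

The expected step is a 1.3-fold lower number from compound 2 to compound 3 (0.10 log units; within the scatter), essentially flat. For compound 3 the estimate in this assay is 11000 nM, within a range of 3500 nM to 35000 nM.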

Compound 3, half-maximal inhibitory concentration: 8000 nM
Compound 3: middle estimate off by 1.4-fold (0.14 log units), on the high side, and the stated range covers the measured number.
By their numbers in this assay, from the lowest: compounds 3, 2 and 1 (each within the scatter of the next, the first and the last beyond it).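

Going by these compounds alone, this is the first measured change on the phenyl of the sulfonyl group. In this assay the step is a 1.8-fold lower number from compound 2 to compound 3 (0.24 log units; within the scatter) on placing trifluoromethoxy on an aromatic carbon, para to a large group, so this position takes a group of 5 heavy atoms without a step beyond the scatter, and compound 2 and compound 3 are not separated by these data. Nothing available bears on the reason for this flat result.

With only hydrogen and trifluoromethoxy shown at this carbon, it remains open whether an amine, a carboxylic acid or a longer alkoxy chain there would also stay within the scatter. Going by these compounds, it is also open whether a second substituent on the same phenyl, or the same trifluoromethoxy group at another carbon of that ring, would give a larger step.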